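The compounds below may be only part of what the source reports. "The series", "measured", "known", "first", "only" and "open" are said of these compounds alone.

In an ADME assay on HEL cells (Homo sapiens) for cytotoxicity (on this read-out higher numbers stand for lower toxicity in this test and lower numbers for higher toxicity in this test), compound 1 `C/C(=N\NC(=O)COc1cccc2ccccc12)c1ccccc1Br` gives 16.2 ug/mL and compound 2 `O=C(COc1cccc2ccccc12)N/N=C/c1cccc([N+](=O)[O-])c1` gives 61.2 ug/mL. Compound 2 therefore holds the higher of the two numbers, and its gap to compound 1 lies beyond the usual scatter of repeat measurements. These two compounds differ in more than one place, so their gap cannot be tied to any single group.

Compound 3 `O=C(COc1cccc2ccccc12)N/N=C/c1cccc(Cl)c1` stays closer to compound 2, with a single exchange: chloro in place of nitro on an aromatic carbon, (chloro in place of nitro on an aromatic carbon). Within the data shown here, no measured pair shows this exchange, so any forecast rests on thin evidence. A small step downward in this assay is expected, of a size that may stay within the scatter. The only reference for a lower number is compound 1, which gives 16.2 ug/mL and also carries no nitro group. The expected change is a 1.7-fold lower number from compound 2 to compound 3 (0.24 log units; within the scatter), and this remains an estimate. For compound 3 the estimated value is 35 ug/mL, with an expected range from 12 ug/mL to 90 ug/mL.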

Compound 3, half-maximal cytotoxic concentration: 58.6 ug/mL
Beside the measured number, compound 3's estimate is 1.7-fold (0.22 log units) below it; measured number inside the range.
By their numbers in this assay, from the lowest: compound 1; then compounds 3 and 2 (each within the scatter of the next).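

In this assay, placing chloro in place of nitro on this aromatic carbon, meta to a large group, gives a 1.0-fold lower number from compound 2 to compound 3 (0.02 log units; within the scatter), so this read-out does not separate the two compounds. At this position, then, a nitro group of 3 heavy atoms, with a double bond and hydrogen-bond acceptors, can give way to a chloro group of a single heavy atom with no hydrogen-bond acceptors, and the number stays within the usual noise of the test; for this pair, the nitro group is not required to keep the number at this level. No accompanying measurement explains why the two groups give such similar readings.

With only nitro and chloro shown at this position, it remains open whether a very different group, such as an amine or a carboxylic acid, would also leave the number unchanged within the scatter. Going by these compounds, it is equally open whether chloro would give a similar number on another carbon of the same ring.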